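Series notes: benzyl in place of anilino on the shared core

This account rests on a few compounds, and the source may have more. Where it says the series, first, only, none or still open, it means among the compounds named here.

The shared core carries a substituent on the aromatic carbon of its five-membered ring, and the set varies that substituent and the aryl group on the other side. Compound 1 `NC(=O)c1cccc(-c2ccc3oc(NC4CCCCC4)nc3c2)c1` bears a cyclohexylamino group; in an assay on HEK293 cells for inhibition of Fatty-acid amide hydrolase 1 (Homo sapiens), read by fluorescence (on this read-out lower numbers stand for stronger inhibition and higher numbers for weaker inhibition), compound 1 gives only a limit, > 1000 nM. Compound 2 `Cn1ccc2cc(-c3ccc4oc(NC5CCCCC5)nc4c3)ccc21` keeps the cyclohexylamino group; in this assay compound 2 gives 911 nM. Compound 3 `Cn1ccc2cc(-c3ccc4oc(Nc5ccccc5)nc4c3)ccc21` has phenyl in place of cyclohexyl on that nitrogen; in this assay compound 3 gives 48 nM, the lowest of the two numbers shown, the other number belonging to compound 2. Among the measured compounds shown here, the step of a 19-fold lower number from compound 2 to compound 3 (1.28 log units; beyond the scatter) is the only measured step in the set.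

Compound 4 `Cn1ccc2cc(-c3ccc4oc(Cc5ccccc5)nc4c3)ccc21` differs from compound 3 by benzyl in place of anilino on an aromatic carbon. For the measured compounds named here, no measured step exchanges the linking nitrogen for a carbon; the step of a 19-fold lower number from compound 2 to compound 3 (1.28 log units; beyond the scatter) concerns the cyclohexyl-to-phenyl exchange alone, with the nitrogen kept in both. Since compound 4 retains the aromatic ring, a loss of the size seen in that step is not expected; a moderate weakening is expected instead, as a 3.1-fold higher number from compound 3 to compound 4 (0.49 log units; beyond the scatter). For compound 4 in this assay the expected value is 150 nM, within 40 nM to 600 nM.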

Compound 4, half-maximal inhibitory concentration: 488 nM
Compound 4: the middle estimate sits 3.3-fold (0.51 log units) below what was measured; the range from low to high includes it.
By their numbers in this assay, from the lowest: compound 3; then compounds 4 and 2 (each within the scatter of the next). At a limit, above all of these: compound 1.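

In this assay, the exchange at this aromatic carbon, next to the ring nitrogen and next to the ring oxygen, gives a 10-fold higher number from compound 3 to compound 4 (1.01 log units; beyond the scatter) while the six-membered aromatic ring of carbon only stays in place, so in this pair the aromatic ring alone does not preserve the number of compound 3. The comparison with the cyclohexylamino group gives a 1.9-fold lower number from compound 2 to compound 4 (0.27 log units; within the scatter) in the same assay, so benzyl and cyclohexylamino cannot be told apart here, and among compounds 2, 3 and 4, which share the same aryl group, only compound 3, with both the linking nitrogen and the aromatic ring, stands apart from the others. Nothing measured here accounts for the loss on going from anilino to benzyl.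

A phenoxy group, with an oxygen as the link, or an anilino group carrying a methyl on its nitrogen, would show whether the linking atom or its hydrogen carries the difference. As far as these compounds go, it also stays open whether the same step holds with the other aryl group of compound 1, which appears here only with cyclohexylamino.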